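This account rests on a few compounds, and the source may have more. Where it says the series, first, only, none or still open, it means among the compounds named here.

In a functional assay on ASPC1 cells (Homo sapiens) for cytotoxicity (on this read-out lower numbers stand for stronger inhibition and higher numbers for weaker inhibition), compound 1 `O=C(CCCCCCC(=O)Nc1nc2ccccc2s1)NO` gives 5.69 ug/mL and compound 2 `Cc1ccc2nc(NC(=O)CCCCCCC(=O)NO)sc2c1` gives 0.54 ug/mL, the lower of the two numbers. Going by the values given here, only one measured step bears on what follows: an 11-fold lower number from compound 1 to compound 2 (1.02 log units; beyond the scatter), with methyl in place of hydrogen on an aromatic carbon. Compound 3 `O=C(CCCCCCC(=O)Nc1nc2ccc([N+](=O)[O-])cc2s1)NO` is still unmeasured. It carries nitro in place of methyl on an aromatic carbon of the six-membered aromatic ring of carbon only: nitro in place of methyl on an aromatic carbon. Among the compounds with values here, the one step shows that a change on this carbon can move this assay well beyond the scatter, but no nitro compound has been measured, so the direction remains uncertain. With compound 2 at the low end at 0.54 ug/mL, a move back toward compound 1 seems the likelier outcome. The expected change is moderate and upward, a 3.0-fold higher number from compound 2 to compound 3 (0.47 log units; beyond the scatter). For compound 3 the estimated value is 1.6 ug/mL, with an expected range from 0.4 ug/mL to 6.5 ug/mL.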

Compound 3, half-maximal inhibitory concentration: 1.65 ug/mL
Compound 3: middle estimate off by 1.0-fold (0.01 log units), on the low side; the range from low to high includes it.
By their numbers in this assay, from the lowest: compound 2; then compound 3; then compound 1.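

In this assay, going by these compounds alone, nitro gives the first comparison between two groups on this aromatic carbon, and the change from methyl gives a 3.1-fold higher number from compound 2 to compound 3 (0.49 log units; beyond the scatter). Against hydrogen, nitro still gives a 3.4-fold lower number from compound 1 to compound 3 (0.54 log units; beyond the scatter), so both groups shown on this carbon give lower numbers than hydrogen, with methyl giving the lower number of the two. Nothing measured here accounts for this order. The compounds shown leave open whether an amine, a methoxy group or a chlorine on this carbon would fall with methyl, with nitro or elsewhere in this order. They also leave open whether the same groups would keep this order on another carbon of the ring, or with a longer chain on the shared core.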